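The source may hold more compounds than are shown below. What is called first, only, known or untested is meant among the compounds shown, and "the series" means these compounds.

Measured compounds:
Compound 1 `C[C@H](NC(=O)Nc1ccccc1F)c1ccccc1`: 98%
Compound 2 `C[C@@H](NC(=O)Nc1cccc(F)c1)c1ccccc1`: 99%
Compound 3 `C[C@H](NC(=O)Nc1ccccc1Cl)c1ccccc1`: 99%

In an ADME assay on the whole organism with Oryza sativa as the target, tested at 0.1 uM (on this read-out lower numbers stand for a stronger effect and higher numbers for a weaker effect at the one concentration tested), compound 1 gives 98%. Compound 3 carries chloro in place of fluoro on an aromatic carbon relative to compound 1, and the step is a number 1 percentage points higher from compound 1 to compound 3 (within the scatter), so the two values cannot be told apart. Compound 2 is built from the same atoms as compound 1, joined differently; the difference between the two cores is not broken down here. In this assay compound 2 gives 99%, level with compound 3 at the digits printed and within the scatter of compound 1. All three measured compounds thus sit close together at the weak end of this read-out at the one concentration tested.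

Compound 4 `C[C@@H](NC(=O)Nc1cccc(Cl)c1)c1ccccc1` is not yet measured. It differs from compound 2 by chloro in place of fluoro on an aromatic carbon. This is the same kind of change as that from compound 1 to compound 3, not the same change: in compound 1 the place is ortho to a large group, in compound 2 it is meta to a large group. Because the earlier step was a number 1 percentage points higher from compound 1 to compound 3 (within the scatter), the expectation for the step from compound 2 to compound 4 in this assay is a number 1 percentage points lower from compound 2 to compound 4 (within the scatter), also within the scatter. Compound 4 is therefore estimated at 98%, with a range from 92% to 100%, resting on the three measured compounds all standing near the same level.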

Compound 4, a percentage reported as activity, at one concentration (the size of the read-out at that concentration, not a potency): 97%
Beside the measured number, compound 4's estimate is 1 percentage points above it; low and high end bracket the measured number.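

In this assay, chloro in place of fluoro on an aromatic carbon of the core of compound 2, meta to a large group, gives a number 2 percentage points lower from compound 2 to compound 4 (within the scatter). Set beside the same kind of change on the core of compound 1, the two steps cannot be told apart: the same change on two cores in this assay, a number 1 percentage points higher (within the scatter) from compound 1 to compound 3 and a number 2 percentage points lower (within the scatter) from compound 2 to compound 4, 3 percentage points apart, within the scatter of two such steps. This shows that the change leaves no readable step on either core in this assay, so the result carries from one core to the other in that limited sense, but all four values sit close together at the weak end of the read-out at the one concentration tested, and a step that is absent there says nothing about how the change would behave on a compound with a clear effect.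

The compounds shown leave open whether anything other than fluoro or chloro on this aromatic ring, such as a nitrile, a trifluoromethyl, a methoxy or an amine, would move the read-out away from this level. They also leave open whether a carboxylic acid or a longer chain elsewhere on the shared core would do so, and whether the fluoro and chloro pairs would then still match.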